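This account rests on a few compounds, and the source may have more. Where it says the series, first, only, none or still open, it means among the compounds named here.

Compound 1 `COc1cc(-c2nn(-c3cccc(NC(=O)Nc4cc(C(F)(F)F)cc(C(F)(F)F)c4)c3)cc2-c2ccncc2)ccc1Cl` and compound 2 `COc1cc(-c2nn(-c3cccc(NC(=O)Nc4cccc(C(F)(F)F)c4)c3)cc2-c2ccncc2)ccc1Cl` share one core and differ only in a single trifluoromethyl group. In a functional assay on K562 cells (Homo sapiens) for inhibition, read by sulforhodamine B assay, with a stated time of 48 h (on this read-out higher numbers stand for weaker inhibition of growth and lower numbers for stronger inhibition of growth), compound 1 gives 3250 nM. Compound 2 reaches only the limit of the assay, > 50000 nM, so for compound 2 there is a limit and not a number. For the measured compounds named here, the step of an at least 15-fold higher number from compound 1 to compound 2 (1.18 log units; beyond the scatter) is the only measured step, and its end point sits at the limit of > 50000 nM in this assay, at which 1 of the 2 values shown sits. Compound 3 `COc1cc(-c2nn(-c3cccc(NC(=O)c4ccccc4)c3)cc2-c2ccncc2)ccc1Cl` differs from compound 2 by phenyl in place of (3-(trifluoromethyl)phenyl)amino on a carbonyl carbon; the whole (3-(trifluoromethyl)phenyl)amino group leaves and a bare phenyl enters on the carbonyl carbon. Going by the values given here, the one measured step, the loss of one trifluoromethyl, already carried compound 2 to the limit, so taking away the remaining trifluoromethyl and the amino as well is expected to leave compound 3 at or past that limit. Compound 3 is therefore expected to give 50000 nM in this assay, within 20000 nM to 150000 nM, an estimated step of a number no higher from compound 2 to compound 3 (the limit leaves the size open).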

Compound 3, concentration for total growth inhibition: > 100000 nM
Compound 3: no number, only a limit; the forecaster's own chance of this, stated with the estimate: 80%; at least 2.0-fold (0.30 log units) between middle value and limit.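

For the compounds shown here, no step from compound 2 to compound 3 can be read, as both results in this assay are limits and not numbers. The compounds shown leave open whether phenyl in place of (3-(trifluoromethyl)phenyl)amino on the carbonyl carbon changes growth inhibition at all.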